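Swapping Phenyl for Piperazin-1-yl in Compound 4

The compounds below may be only part of what the source reports. "The series", "measured", "known", "first", "only" and "open" are said of these compounds alone.

Of the compounds shown here, three sharing one core have been measured in a functional assay on HUVEC cells (Homo sapiens), read by scintillation counting and thymidine incorporation, with a stated time of 24 h; on this read-out lower numbers stand for stronger inhibition and higher numbers for weaker inhibition. Compound 1 `CCC(C)n1ncn(-c2ccc(N3CCN(c4ccc(OC[C@@H]5COC(c6ccc(Cl)cc6Cl)O5)cc4)CC3)cc2)c1=O` gives 328 nM. Compound 2 `CCC(C)n1ncn(-c2ccc(N3CCN(c4ccc(OC[C@@H]5CO[C@@](CBr)(c6ccc(Cl)cc6Cl)O5)cc4)CC3)cc2)c1=O` carries bromo on a saturated chain carbon bound to a saturated ring carbon, and in this assay compound 2 gives 569 nM. Compound 3 `CCC(C)n1ncn(-c2ccc(N3CCN(c4ccc(OC[C@@H]5CO[C@@](Cc6ccccc6)(c6ccc(Cl)cc6Cl)O5)cc4)CC3)cc2)c1=O` has phenyl in that place; in this assay compound 3 gives 513 nM, the second highest of the three numbers, and its gap to compound 2 as well as to compound 1 lies within the scatter. Going by the values given here, the one measured step at this position, a 1.1-fold lower number from compound 2 to compound 3 (0.04 log units; within the scatter), was small.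

Compound 4 `CCC(C)n1ncn(-c2ccc(N3CCN(c4ccc(OC[C@@H]5CO[C@@](CN6CCNCC6)(c6ccc(Cl)cc6Cl)O5)cc4)CC3)cc2)c1=O` is the next member of the series: piperazin-1-yl in place of phenyl on a saturated chain carbon bound to a saturated ring carbon. Among the compounds with values here, only the step from compound 2 to compound 3 bears on this change, and that step stayed within the scatter, so the group on this saturated chain carbon has so far moved the number little. Within the data shown here, no measured compound carries a non-aromatic ring with hetero atoms in this place, so the new group is untested. The expected step is therefore a 1.0-fold lower number from compound 3 to compound 4 (0.01 log units; within the scatter), nothing beyond the scatter. Compound 4 is accordingly estimated at 500 nM, with a range from 180 nM to 1400 nM.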

Compound 4, half-maximal inhibitory concentration: 608 nM
Beside the measured number, compound 4's estimate is 1.2-fold (0.08 log units) below it; the range from low to high includes it.
By their numbers in this assay, from the lowest: compounds 1, 3, 2 and 4 (each within the scatter of the next).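

In this assay, going by these compounds alone, piperazin-1-yl is the first non-aromatic ring with hetero atoms on this saturated chain carbon bound to a saturated ring carbon, and it gives a 1.2-fold higher number from compound 3 to compound 4 (0.07 log units; within the scatter) and a 1.1-fold higher number from compound 2 to compound 4 (0.03 log units; within the scatter). Together with the earlier step, these results place bromo, phenyl and piperazin-1-yl within the scatter of one another at this position, so the range of groups that leave the number essentially unmoved now covers a halogen, an all-carbon aromatic ring and a ring containing nitrogen, and the exchange of benzyl for (piperazin-1-yl)methyl, which brings in a hydrogen-bond donor and acceptors that phenyl lacks, produces no step beyond the scatter. No supporting measurement bears on this result, so the comparison rests on the numbers alone.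

The compounds shown leave open whether a carboxylic acid, an open-chain amine or a longer chain in this place would also stay within the scatter of these three. They also leave open whether an acetyl group on the piperazin-1-yl ring would move the number.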